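The compounds below may be only part of what the source reports. "The series", "measured", "known", "first", "only" and "open" are said of these compounds alone.

Measured compounds in a functional assay on HBL-100 cells (Homo sapiens) for inhibition, read by sulforhodamine B assay, with a stated time of 48 h; on this read-out higher numbers stand for weaker inhibition of growth and lower numbers for stronger inhibition of growth:
compound 1 `COC(=O)[C@@]1(C)CCC=C2[C@@H]1CC[C@@H](C)[C@]2(C)Cc1c[nH]c2c(C)cccc12` gives 8000 nM
compound 2 `COC(=O)[C@@]1(C)CCC=C2[C@@H]1CC[C@@H](C)[C@]2(C)Cc1c(C)[nH]c2ccccc12` gives 14000 nM
compound 3 `COC(=O)[C@@]1(C)CCC=C2[C@@H]1CC[C@@H](C)[C@]2(C)Cc1c(C)[nH]c2ccc(Br)cc12` gives 15000 nM

Compound 2 stands second highest of the three numbers in this assay. Its nearest neighbour is compound 3, within the scatter, and compound 1 also lies within the scatter of compound 2, so no order among the three can be claimed.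

Compound 4 `COC(=O)[C@@]1(C)CCC=C2[C@@H]1CC[C@@H](C)[C@]2(C)Cc1c(C)[nH]c2c(C)cccc12` is not yet measured. It differs from compound 2 by methyl in place of hydrogen on an aromatic carbon. Among the compounds with values here, compound 1 also bears a methyl on a six-membered aromatic ring of carbon only, but it differs from compound 2 in a second place as well, so no single step connects the two; their values sit within the scatter of each other. Within the data shown here, the one measured step at an aromatic carbon of this ring, a 1.1-fold higher number from compound 2 to compound 3 (0.03 log units; within the scatter), changed nothing beyond the scatter. On that basis the added methyl is not expected to move the number beyond the scatter either. Compound 4 is expected at 11000 nM, with a range from 5000 nM to 25000 nM. The expected step is a 1.3-fold lower number from compound 2 to compound 4 (0.10 log units; within the scatter).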

Compound 4, concentration for 50% growth inhibition: 16000 nM
Compound 4: middle estimate off by 1.5-fold (0.16 log units), on the low side; measured number inside the range.
By their numbers in this assay, from the lowest: compounds 1, 2, 3 and 4 (each within the scatter of the next).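

In this assay, within the data shown here, the methyl on the aromatic carbon ortho to a fused ring and meta to a fused ring gives a 1.1-fold higher number from compound 2 to compound 4 (0.06 log units; within the scatter) and so shows that this position, which had not carried a substituent in the earlier compounds, takes a methyl without a change beyond the scatter. The same methyl-for-hydrogen change read at a different aromatic carbon gives a 2.0-fold higher number from compound 1 to compound 4 (0.30 log units; within the scatter) and so adds a second site where a methyl leaves the number within the scatter. No data at hand bear on why these steps stay so small.

On these data alone, whether an amine, a carboxylic acid or a longer chain on this aromatic carbon would move the number beyond the scatter stays open. With no step shown leaving the scatter, it also stays open which part of the shared core the number responds to.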